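Hydroxy to methoxy on compound 2

The source may hold more compounds than are shown below. What is called first, only, known or untested is meant among the compounds shown, and "the series" means these compounds.

In an in vivo ADME assay on the whole organism (plasma) for pharmacokinetics, with Rattus norvegicus as the target, at a dose of 50 mg/kg by the oral route (a lower number here means less compound in the circulation, a higher number more compound in the circulation at the dose given), compound 2 `C/C(=N\O)c1cc(C)cc(C)c1NC(=O)c1sccc1S(=O)(=O)Nc1onc(C)c1Cl` stands lowest of the two numbers at 14300 nM and compound 1 `Cc1cc(C)c(NC(=O)c2sccc2S(=O)(=O)Nc2onc(C)c2Cl)c(C)c1` stands higher at 81600 nM on the same dose. Compound 3 `CO/N=C(\C)c1cc(C)cc(C)c1NC(=O)c1sccc1S(=O)(=O)Nc1onc(C)c1Cl` differs from compound 2 as hydroxy to methoxy: methyl in place of hydrogen on an oxygen with methyl in place of hydrogen on an oxygen. Among the compounds with values here, one measured step bears on this only indirectly: a 5.7-fold lower number from compound 1 to compound 2 (0.76 log units; beyond the scatter) is modest and brought in the group now altered. Within the data shown here, no measured step covers the change itself, so a smaller move is expected, with a 1.3-fold higher number from compound 2 to compound 3 (0.10 log units; within the scatter) as the estimated step and none beyond the scatter anticipated. Compound 3 is estimated at 18000 nM with an expected range of 6000 nM to 55000 nM in this read-out.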

Compound 3, maximal plasma concentration: 27800 nM
Estimate against measurement, compound 3: 1.5-fold (0.19 log units) below; the range from low to high includes it.
By their numbers in this assay, from the lowest: compounds 2 and 3 (each within the scatter of the next); then compound 1.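

In this assay, methyl in place of hydrogen on the oxygen gives a 1.9-fold higher number from compound 2 to compound 3 (0.29 log units; within the scatter), so hydroxy and methoxy cannot be told apart at this position. The group on the aromatic carbon still carries a step beyond the scatter with methoxy in it: a 2.9-fold lower number from compound 1 to compound 3 (0.47 log units; beyond the scatter). No measurement at hand explains either step. Open, from the compounds shown here alone, is whether a longer chain on this oxygen, such as ethyl or benzyl, would stay within the scatter of these numbers. Also open, going by these compounds, is what an amine on the nitrogen, in place of methoxy, would give.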